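A few compounds are considered here, and "the series" means these few. Any claim that something is new, unique, unknown or untested is made for them only; others in the source may bear on it.

Measured so far in a functional assay on HOP-92 cells (Homo sapiens) for inhibition, read by sulforhodamine B assay, with a stated time of 48 h; on this read-out higher numbers stand for weaker inhibition of growth and lower numbers for stronger inhibition of growth:
compound 1 `COc1ccc(-c2[nH]c3ccc(OC)cc3c2/C=C(\C#N)S(=O)(=O)c2ccccc2)cc1` — 698 nM
compound 2 `CC(=O)/C(=C\c1c(-c2ccccc2)[nH]c2ccccc12)S(=O)(=O)c1ccccc1` — 5900 nM
compound 3 `COc1ccc(-c2[nH]c3ccc(OC)cc3c2C=C(C#N)C#N)cc1` — 23000 nM

Compound 2 stands second highest of the three numbers, nearest to compound 3 and furthest from compound 1. Compound 4 `N#C/C(=C\c1c(-c2ccccc2)[nH]c2ccccc12)S(=O)(=O)c1ccccc1` is the next compound, not yet measured. Against compound 2 the change is cyano in place of acetyl on a double-bonded chain carbon bound to a double-bonded chain carbon and a sulfonyl sulfur. Among the compounds with values here, no single-change pair is available to size this step directly. Compound 1 also carries cyano at that place and gives the lowest number of the three, but differs elsewhere as well, so only a loose pointer. A moderate lowering of the number is expected, likely beyond the scatter, as a 3.0-fold lower number from compound 2 to compound 4 (0.47 log units; beyond the scatter). Compound 4 is estimated at 2000 nM, within 500 nM to 8000 nM.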

Compound 4, concentration for 50% growth inhibition: 10300 nM
For compound 4 the middle estimate is 5.2-fold (0.71 log units) below the measured one, and the stated range ends below it.
By their numbers in this assay, from the lowest: compound 1; then compounds 2 and 4 (each within the scatter of the next); then compound 3.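

In this assay cyano in place of acetyl on a double-bonded chain carbon bound to a double-bonded chain carbon and a sulfonyl sulfur gives a 1.7-fold higher number from compound 2 to compound 4 (0.24 log units; within the scatter) and so leaves the two groups unseparated at this place. Within the data shown here, on the core shared by compound 2 and compound 4, this position so far tolerates either group with no readable change in growth inhibition. No measurement at hand accounts for this result.

Still open, on these data alone, is whether a methyl ester or a primary carboxamide at this place would move the number beyond the scatter. Also open, as far as these compounds go, is whether the same swap behaves alike on a core carrying methoxy groups.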